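This account rests on a few compounds, and the source may have more. Where it says the series, first, only, none or still open, it means among the compounds named here.

Measured compounds:
compound 1, `Cc1cccc(NNC(=O)c2ccc(NS(=O)(=O)c3cnc(O)nc3O)cc2)c1`, > 20000 nM in a functional assay on MDA-MB-231 cells (Homo sapiens) for antiproliferative activity, read by MTT assay, with a stated time of 24 h; on this read-out lower numbers stand for stronger inhibition and higher numbers for weaker inhibition
compound 2, `O=C(NNc1ccccc1Cl)c1cccc(NS(=O)(=O)c2cnc(O)nc2O)c1`, 2090 nM
compound 3, `O=C(NNc1cccc(Cl)c1)c1ccccc1NS(=O)(=O)c1cnc(O)nc1O`, 11800 nM

Compound 1 sits at a limit of the assay, not at a measured number; the value the limit of > 20000 nM in this assay, at which 1 of the 3 values shown sits, only says that no inhibition strong enough to be read was found at the highest concentration tested. Compound 2 and compound 3 do give numbers, and the value of compound 2 is the stronger of the two.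

Compound 4, `O=C(NNC(=O)c1ccc(NS(=O)(=O)c2cnc(O)nc2O)cc1)c1ccc(F)cc1`, has not yet been measured. It differs from compound 1 by (4-fluorophenyl)carbonyl in place of 3-methylphenyl on an amine nitrogen. Going by the values given here, no pair of measured compounds shows the effect of this change, so there is no measured guide for its size or direction. With compound 1 at the limit, a step toward weaker inhibition cannot be seen at all, and only a large move toward stronger inhibition would register. The expectation is that compound 4 stays near the limit, and the step of an at least 1.3-fold lower number from compound 1 to compound 4 (0.12 log units; that floor lies within the scatter) is estimated as none beyond the scatter. Compound 4 is therefore expected to give about 15000 nM, within 3000 nM to 60000 nM.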

Compound 4, half-maximal inhibitory concentration: > 20000 nM
Compound 4 was reported as a limit; the forecaster's own chance of this, stated with the estimate: 55%; middle value at least 1.3-fold (0.12 log units) from the limit.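

Going by these compounds alone, compound 1 and compound 4 both sit at a limit rather than at a measured number, so no step between them can be read: the limit of > 20000 nM in this assay, at which 2 of the 4 values shown sit. The compounds shown leave open whether (4-fluorophenyl)carbonyl in place of 3-methylphenyl on an amine nitrogen changes inhibition at all.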